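The source may hold more compounds than are shown below. What is called first, only, known or untested is meant among the compounds shown, and "the series" means these compounds.

Within the data shown here, in an ADME assay on microsomes from liver (Homo sapiens) for metabolic stability (on this read-out lower numbers stand for a shorter-lived compound and higher numbers for a longer-lived compound), compound 2 `O=C1NC(=O)/C(=C/C(c2ccc(-c3ccc4cccc(F)c4c3)[nH]c2=O)C2CCCCC2)O1` gives 1.09 h, the only exact number so far. Compound 1 `CCC(CC)C(/C=C1\OC(=O)NC1=O)c1ccc(-c2ccc3cccc(F)c3c2)[nH]c1=O` gives > 3 h, which is a limit of the assay and not a number. Compound 3 `O=C1NC(=O)/C(=C/C(c2ccc(-c3ccc4cccc(F)c4c3)[nH]c2=O)C2CC2)O1` differs from compound 2 in one group: cyclopropyl in place of cyclohexyl on a saturated chain carbon bound to an aromatic carbon and a double-bonded chain carbon. Here cyclopropyl stands in place of cyclohexyl on a saturated chain carbon bound to an aromatic carbon and a double-bonded chain carbon. Among the measured compounds shown here, only one measured step bears on this place: cyclohexyl replacing pentan-3-yl gave an at least 2.7-fold lower number from compound 1 to compound 2 (0.43 log units; beyond the scatter). Compound 3 loses the cyclohexyl that came with that drop, so a longer half-life is expected, although a single step with a different incoming group is thin support. In this assay, the expected change is a 2.2-fold higher number from compound 2 to compound 3 (0.34 log units; beyond the scatter). For compound 3, the estimated half-life is 2.4 h, with an expected range of 1.1 h to 5 h.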

Compound 3, half-life: 1.98 h
The estimate for compound 3 lay 1.2-fold (0.08 log units) above the measured number; measured number inside the range.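

In this assay, cyclopropyl in place of cyclohexyl on a saturated chain carbon bound to an aromatic carbon and a double-bonded chain carbon gives a 1.8-fold higher number from compound 2 to compound 3 (0.26 log units; within the scatter) and so does not tell these two rings apart at this position. Cyclopropyl in place of pentan-3-yl gives an at least 1.5-fold lower number from compound 1 to compound 3 (0.18 log units; that floor lies within the scatter) and so, unlike cyclohexyl, cyclopropyl is not yet set apart from the open pentan-3-yl group. This comparison has only a floor to work with, since compound 1 carries a limit and not a number: the limit of > 3 h in this assay, at which 1 of the 3 values shown sits.

Going by these compounds, how far the half-life of compound 1 really extends past that limit stays unknown. The compounds shown also leave open how an isopropyl group, or a ring holding an oxygen such as tetrahydropyranyl, would fare at this carbon.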